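From compound 1 to compound 3: adding a formyl

The compounds below may be only part of what the source reports. "The series", "measured", "known", "first", "only" and "open" are said of these compounds alone.

Compound 1 `Cc1ccc(-c2cc(N)n(-c3ccc(Br)cc3)n2)cc1` is the reference point here. Going by the values given here, in a functional assay on NPC-TW01 cells (Homo sapiens) for inhibition, read by MTT assay, with a stated time of 72 h (a higher number here means a weaker inhibitor of growth, a lower number a stronger inhibitor of growth), compound 1 gives 80200 nM, the only true number available so far. Its relative compound 2 `Cc1ccc(-c2cc(/N=C/N(C)C)n(-c3ccc(Br)cc3)n2)cc1` gives > 100000 nM, which is a limit of the assay and not a number.

Compound 3 `Cc1ccc(-c2nn(-c3ccc(Br)cc3)c(N)c2C=O)cc1` keeps the core of compound 1 and carries one change: formyl in place of hydrogen on an aromatic carbon. The formyl sits on an aromatic carbon next to the ring atom that bears an amino group and next to the ring atom that bears a 4-methylphenyl group.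

Among the compounds with values here, only one measured step can serve as a guide, an at least 1.2-fold higher number from compound 1 to compound 2 (0.09 log units; that floor lies within the scatter), and its floor lies within the scatter. That step alters a different place on the core, at the amino group, so it offers only weak guidance on a new formyl. With no firm sign of direction or size, no change beyond the scatter is expected in this assay, and a limit remains possible.

The expected step is a 1.5-fold lower number from compound 1 to compound 3 (0.16 log units; within the scatter). For compound 3 the estimated value is 55000 nM, with an expected range from 15000 nM to 100000 nM.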

Compound 3, concentration for 50% growth inhibition: 28200 nM
The estimate for compound 3 lay 2.0-fold (0.29 log units) above the measured number; the range from low to high includes it.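

In this assay formyl in place of hydrogen gives a 2.8-fold lower number from compound 1 to compound 3 (0.45 log units; beyond the scatter) and this is the first step among these compounds with a size beyond the scatter. The earlier change, at the amino group, ended in a limit for compound 2 and gave no firm direction, whereas this step shows that the aromatic carbon carrying only hydrogen in compound 1 can take a small group while the number falls rather than rises. The gain is modest, since compound 3 still gives 28200 nM in this assay, and nothing measured here explains why formyl lowers the number.

A single group at this carbon cannot show whether the formyl itself matters or whether other groups, such as a carboxylic acid, a nitrile or a longer chain ending in an amine, would lower the number further or raise it again. As far as these compounds go, it also remains open whether the effect of formyl depends on the free amino group on the neighbouring ring atom, or would persist if that amino group were replaced by the longer group carried by compound 2.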